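This account rests on a few compounds, and the source may have more. Where it says the series, first, only, none or still open, it means among the compounds named here.

Working notes on the series. Three measured compounds share one core and differ only in the aryl group on the saturated chain carbon: compound 1 (`Cc1oc2c([C@H]3CCN(C)C[C@H]3O)c(O)cc(O)c2c(=O)c1C(O)c1cccc(Cl)c1`), compound 2 (`Cc1oc2c([C@H]3CCN(C)C[C@H]3O)c(O)cc(O)c2c(=O)c1C(O)c1ccc(F)c(Br)c1`) and compound 3 (`Cc1oc2c([C@H]3CCN(C)C[C@H]3O)c(O)cc(O)c2c(=O)c1C(O)c1c(Cl)cccc1Cl`). In a functional assay on HL-60 cells (Homo sapiens) for inhibition, read by MTT assay, with a stated time of 48 h, tested at 10 uM (on this read-out higher numbers stand for more inhibition of growth at the one concentration tested and lower numbers for less inhibition of growth), compound 1 gives 22% and compound 2 gives 25% while compound 3 gives 14% (within the scatter of compound 1, and apart from compound 2 only).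

The next entry is compound 4 (`Cc1oc2c([C@H]3CCN(C)C[C@H]3O)c(O)cc(O)c2c(=O)c1C(O)c1csc([N+](=O)[O-])c1`), which carries 5-nitrothiophen-3-yl in place of 2,6-dichlorophenyl on a saturated chain carbon bound to an aromatic carbon and an oxygen on a saturated carbon.

Within the data shown here, three measured steps bear on this change, all at that same place: (a number 3 percentage points higher from compound 1 to compound 2 (within the scatter)) and (a number 8 percentage points lower from compound 1 to compound 3 (within the scatter)) and (a number 11 percentage points lower from compound 2 to compound 3 (beyond the scatter)). Only the last passes the scatter, and it is modest. Among the measured compounds shown here, none of the three brings in a five-membered aromatic ring or a nitro group, so the entering group has no direct measured counterpart and the range stays wide.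

The estimated change is a number 6 percentage points higher from compound 3 to compound 4 (within the scatter) and so no step beyond the scatter is expected in this assay for this exchange. For compound 4 the estimate is 20% (expected range 8% to 36%).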

Compound 4, percent growth inhibition at one concentration: 45%
Estimate against measurement, compound 4: 25 percentage points below; measured number outside the range, above it.
By their numbers in this assay, from the lowest: compounds 3, 1 and 2 (each within the scatter of the next, the first and the last beyond it); then compound 4.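

In this assay, the aryl group on the saturated chain carbon bound to an aromatic carbon and an oxygen on a saturated carbon proves able to move the read-out well beyond the scatter: 5-nitrothiophen-3-yl in place of 2,6-dichlorophenyl gives the largest step seen so far (a number 31 percentage points higher from compound 3 to compound 4 (beyond the scatter)). The same entering group also clears the other two halogenated phenyl groups (a number 20 percentage points higher from compound 2 to compound 4 (beyond the scatter)) and (a number 23 percentage points higher from compound 1 to compound 4 (beyond the scatter)), so compound 4 stands highest of the four, and none of the shown compounds goes against this order. Among the earlier compounds, exchanges between halogenated phenyl groups gave at most a modest step, whereas this exchange, with its five-membered aromatic ring and nitro group, shows a much wider span at this place, and no measurement at hand gives a reason for the result.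

The ring and the nitro group enter together in compound 4, so their shares in the step stay unseparated; a nitrophenyl group and a thiophene ring bearing no nitro group would divide them. Also open, going by these compounds, is whether an amine or a carboxylic acid in place of the nitro group would hold the number at this place.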